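Isopropyl to tert-butyl on the amide of compound 2

This account rests on a few compounds, and the source may have more. Where it says the series, first, only, none or still open, it means among the compounds named here.

Of the compounds shown here, three sharing one core have been measured in a functional assay on HT-29 cells (Homo sapiens) for antiproliferative activity, read by MTT assay, with a stated time of 72 h, tested at 10 uM; on this read-out higher numbers stand for more inhibition at the one concentration tested (going by the name of the read-out) and lower numbers for less inhibition. Compound 1 `CCn1cc(-c2ccc(F)cc2)c(=O)c2c(Nc3ccc(Oc4ccnc(NC(=O)C5CC5)c4)c(F)c3)nccc21` gives 15.8%, compound 3 `Cn1cc(-c2ccc(F)cc2)c(=O)c2c(Nc3ccc(Oc4ccnc(NC(=O)C5CC5)c4)c(F)c3)nccc21` gives 24.8%, and compound 2 `CC(C)C(=O)Nc1cc(Oc2ccc(Nc3nccc4[nH]cc(-c5ccc(F)cc5)c(=O)c34)cc2F)ccn1` gives 83.4%, the highest of the three, with gaps to both others beyond the scatter. Within the data shown here, the only single-point step measured, a number 9 percentage points higher from compound 1 to compound 3 (within the scatter), sits at the aromatic nitrogen, far from the amide, so it does not bear on the change at hand. Compound 4 `CC(C)(C)C(=O)Nc1cc(Oc2ccc(Nc3nccc4[nH]cc(-c5ccc(F)cc5)c(=O)c34)cc2F)ccn1` differs from compound 2 by methyl in place of hydrogen on a saturated chain carbon bound to a carbonyl carbon and two saturated chain carbons. Among the measured compounds shown here, with no matching step available, a small shift is expected, a number 7.4 percentage points lower from compound 2 to compound 4 (within the scatter). Compound 4 is therefore estimated at 76%, within 55% to 92%.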

Compound 4, a percentage reported as inhibition, at one concentration (the size of the read-out at that concentration, not a potency): -45.8%
Estimate against measurement, compound 4: 121.8 percentage points above, outside the stated range (below it).
By their numbers in this assay, from the lowest: compound 4; then compounds 1 and 3 (each within the scatter of the next); then compound 2.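

On the amide of compound 2, one added methyl, turning isopropyl into tert-butyl, goes with a number 129.2 percentage points lower from compound 2 to compound 4 (beyond the scatter), so this single carbon weighs heavily on the read-out for this core. The earlier compounds gave no hint of this, and swapping methyl and hydrogen carries no fixed size from one place to another: the same change on two cores in this assay, a number 9 percentage points higher (within the scatter) from compound 1 to compound 3 and a number 129.2 percentage points higher (beyond the scatter) from compound 4 to compound 2, 120.2 percentage points apart, beyond the scatter of two such steps

Still open, from the compounds shown here alone, is how the number behaves with other groups at this carbon, such as a longer straight chain or an amine. Why tert-butyl has this effect also remains unanswered.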